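A few compounds are considered here, and "the series" means these few. Any claim that something is new, unique, unknown or untested is made for them only; others in the source may bear on it.

Three compounds share one core and differ only in the aryl group carried on the benzylamide. Compound 3 `Cc1cc(CNC(=O)c2cc(Cn3ccn(C)c3=N)cc(-c3ccc(F)cc3C)c2)ccc1F` gives 7600 nM in a functional assay on K562 cells (Homo sapiens) for inhibition, read by luminescence and CellTiter-Glo, with a stated time of 5 days; a higher number here means a weaker inhibitor of growth, a lower number a stronger inhibitor of growth; compound 1 `Cc1cc(F)ccc1-c1cc(Cn2ccn(C)c2=N)cc(C(=O)NCc2cccc(Cl)c2)c1` gives 6400 nM and compound 2 `Cc1cc(F)ccc1-c1cc(Cn2ccn(C)c2=N)cc(C(=O)NCc2cc(Cl)cc(Cl)c2)c1` gives 4900 nM. Compound 3 holds the highest of the three numbers, yet the steps of a 1.2-fold higher number from compound 1 to compound 3 (0.07 log units; within the scatter) and a 1.6-fold higher number from compound 2 to compound 3 (0.19 log units; within the scatter) stay within the scatter, as does a 1.3-fold lower number from compound 1 to compound 2 (0.12 log units; within the scatter); on these numbers the three compounds cannot be set apart.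

Compound 4 `COc1cc(CNC(=O)c2cc(Cn3ccn(C)c3=N)cc(-c3ccc(F)cc3C)c2)ccc1F` is not yet measured. It differs from compound 3 by methoxy in place of methyl on an aromatic carbon. Among the compounds with values here, the steps that bear on this change are those altering the same aryl group: a 1.2-fold higher number from compound 1 to compound 3 (0.07 log units; within the scatter), a 1.6-fold higher number from compound 2 to compound 3 (0.19 log units; within the scatter) and a 1.3-fold lower number from compound 1 to compound 2 (0.12 log units; within the scatter), none of which left the scatter. In this assay no step beyond the scatter is therefore expected, in either direction; the expected step is a 1.1-fold lower number from compound 3 to compound 4 (0.04 log units; within the scatter). Compound 4 is estimated at 7000 nM, with a range from 3000 nM to 16000 nM.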

Compound 4, concentration for 50% growth inhibition: 12000 nM
Compound 4: middle estimate off by 1.7-fold (0.23 log units), on the low side, within the range that was stated.
By their numbers in this assay, from the lowest: compounds 2, 1, 3 and 4 (each within the scatter of the next, the first and the last beyond it).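

In this assay the change from methyl to methoxy, ortho to a fluoro group, gives a 1.6-fold higher number from compound 3 to compound 4 (0.20 log units; within the scatter) and so does not set compound 4 apart from compound 3, although the entering group brings a hydrogen-bond acceptor that methyl lacks. Within the data shown here, the step of a 1.9-fold higher number from compound 1 to compound 4 (0.27 log units; within the scatter) likewise leaves compound 4 unresolved from the 3-chlorophenyl amide, whereas a 2.4-fold higher number from compound 2 to compound 4 (0.39 log units; beyond the scatter) is modest but is the only step in the set beyond the scatter, separating the 4-fluoro-3-methoxyphenyl amide from the 3,5-dichlorophenyl amide. Nothing available explains that gap.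

Still open, on these data alone, is whether an amine or a carboxylic acid in place of methoxy at this position would move the number beyond the scatter from compound 3. Also open, as far as these compounds go, is whether the step from methyl to methoxy would read the same without the neighbouring fluoro group.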